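Swapping Hydroxy for Chloro: An Expected Growth-Inhibition Value

A few compounds are considered here, and "the series" means these few. Any claim that something is new, unique, unknown or untested is made for them only; others in the source may bear on it.

Measured so far:
- compound 1 `COc1ccc(C(=O)/C=C/c2cc3ccccc3[nH]c2=O)cc1` gives 4400 nM in a functional assay on EKVX cells (Homo sapiens) for cytotoxicity, read by sulforhodamine B assay, with a stated time of 24 h; on this read-out lower numbers stand for stronger inhibition of growth and higher numbers for weaker inhibition of growth
- compound 2 `O=C(/C=C/c1cc2ccccc2[nH]c1=O)c1ccc(O)cc1` gives 13400 nM in this assay

Among these two numbers compound 2 stands highest, meaning the weaker inhibitor of growth. Among the compounds with values here, its only neighbour is compound 1, and the step of a 3.0-fold higher number from compound 1 to compound 2 (0.48 log units; beyond the scatter) shows that putting a hydrogen in place of the methyl on the ring oxygen weakened the effect by a modest but real amount.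

Compound 3 `O=C(/C=C/c1cc2ccccc2[nH]c1=O)c1ccc(Cl)cc1` has not yet been tested. Going from compound 2 to compound 3 the change is chloro in place of hydroxy on an aromatic carbon, which sits on an aromatic carbon of a six-membered aromatic ring of carbon only, para to a large group; read one bond further out, 4-hydroxyphenyl becomes 4-chlorophenyl.

Within the data shown here, no measured step covers exactly this exchange. Among the measured compounds shown here, the one step available, a 3.0-fold higher number from compound 1 to compound 2 (0.48 log units; beyond the scatter), shows that removing the free hydroxy in favour of a group with no hydrogen-bond donor gave a lower number, so a chloro, which likewise carries no donor and no acceptor, is expected to move the number downward by a similar modest amount rather than upward. Compound 3 is therefore expected to give about 5000 nM in this assay, with a likely range from 1500 nM to 17000 nM. That estimate corresponds to a step of a 2.7-fold lower number from compound 2 to compound 3 (0.43 log units; beyond the scatter).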

Compound 3, concentration for 50% growth inhibition: 4920 nM
The estimate for compound 3 lay 1.0-fold (0.01 log units) above the measured number, within the range that was stated.
By their numbers in this assay, from the lowest: compounds 1 and 3 (each within the scatter of the next); then compound 2.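

In this assay, the position para to a large group now carries three different groups, and the hydroxy stands apart: swapping it for chloro gives a 2.7-fold lower number from compound 2 to compound 3 (0.44 log units; beyond the scatter), whereas chloro in place of methoxy gives a 1.1-fold higher number from compound 1 to compound 3 (0.05 log units; within the scatter), so these two groups cannot be told apart here. The earlier single step could not settle whether methoxy was unusually good or hydroxy was the odd one out; now compound 2 alone has the highest number, while the two groups without a hydrogen-bond donor sit together. That link to the donor is only a pattern across three compounds, and nothing measured here explains it.

From the compounds shown here alone, it remains open whether an amine or a carboxylic acid at this position would read like the hydroxy or like chloro and methoxy, and the same question applies to a longer chain such as butoxy. Going by these compounds, it is also open whether the gap between the hydroxy and the other two groups would persist with these groups placed elsewhere on the ring or in other cell lines.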